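The compounds below may be only part of what the source reports. "The series", "measured", "known", "first", "only" and "open" are said of these compounds alone.

Measured so far:
compound 1, `CCCCCCNC(=O)/C=C/c1ccccc1`: 55%
compound 2, `CC(C)NC(=O)/C=C/c1ccccc1`: 39%

In a functional assay on the whole organism for inhibition, with Brassica rapa subsp. chinensis as the target, with a stated time of 3 days, tested at 100 ppm (a lower number here means less inhibition of growth, a higher number more inhibition of growth at the concentration tested), compound 1 gives 55%, the highest of the two numbers on hand. Compound 2 gives 39%, a gap beyond the scatter. Compound 3, `CCCCCCCCNC(=O)/C=C/c1ccccc1`, is still to be measured in this assay. It differs from compound 1 by ethyl in place of hydrogen on a saturated chain carbon, six bonds along the chain from an amide-type nitrogen. Going by the values given here, no step between two measured compounds covers this kind of change, so its size is not known from the series itself; the pair compound 1 against compound 2 differs in another way and shows only that the hexyl chain gives the higher number of the two. On that thin basis a small upward step or none beyond the scatter is expected. The step of a number 3 percentage points higher from compound 1 to compound 3 (within the scatter) is estimated to stay close to the scatter. Compound 3 is expected to give about 58% in this assay, with a range from 40% to 75%.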

Compound 3, percent growth inhibition at one concentration: 34%
Beside the measured number, compound 3's estimate is 24 percentage points above it; measured number outside the range, below it.
By their numbers in this assay, from the lowest: compounds 3 and 2 (each within the scatter of the next); then compound 1.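

The change of ethyl in place of hydrogen on a saturated chain carbon, six bonds along the chain from an amide-type nitrogen, gives a number 21 percentage points lower from compound 1 to compound 3 (beyond the scatter) in this assay and so is not a neutral extension at this position. Growth inhibition therefore does not simply rise as this chain is extended: for this one pair, the extended chain of compound 3 gives the lower number and the hexyl chain of compound 1 the higher.

The compounds shown leave open whether the fall sets in gradually or abruptly, since a heptyl chain is absent from them. They also leave open whether a still longer chain such as decyl would fall further, and whether a hydroxyl group at the chain end would be tolerated. Nothing measured on hand accounts for the fall at this position.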